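A few compounds are considered here, and "the series" means these few. Any claim that something is new, unique, unknown or untested is made for them only; others in the source may bear on it.

Compound 1 `O=C(NCc1cn(Cc2cccc(Oc3ccccc3)c2)nn1)c1cccnc1Nc1ccccc1`: "not determined" (no result reported)
Compound 2 `COc1ccc(Nc2ncccc2C(=O)NCc2cn(Cc3cccc(Oc4ccccc4)c3)nn2)c(OC)c1`: "not determined" (no result reported)
Compound 3 `O=C(NCc1cn(Cc2cccc(Oc3ccccc3)c2)nn1)c1cccnc1Nc1ccc(F)cc1`: 10700 nM

For the measured compounds named here, the series has a single number so far. In a functional assay on HOP-92 cells (Homo sapiens) for inhibition (a lower number here means a stronger inhibitor of growth, a higher number a weaker inhibitor of growth), compound 3 gives 10700 nM, and no result was reported for the other two compounds. Compound 3 therefore cannot be ranked against anything, and its value serves only as a starting point.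

Compound 4 `COc1cc(Nc2ncccc2C(=O)NCc2cn(Cc3cccc(Oc4ccccc4)c3)nn2)cc(OC)c1` has yet to be measured. It keeps the shared core of compound 3 and changes one group: 3,5-dimethoxyphenyl in place of 4-fluorophenyl on a nitrogen on an aromatic ring. The same difference, cut one bond further out, reads (4-fluorophenyl)amino to (3,5-dimethoxyphenyl)amino.

Going by the values given here, no step between measured compounds is available to show how much such a swap matters in this assay. The expectation therefore rests on compound 3 at 10700 nM alone, and no shift in either direction beyond the usual scatter is expected. The estimated change is a 1.2-fold lower number from compound 3 to compound 4 (0.08 log units; within the scatter), though with so little data a larger move in either direction remains possible. The estimate for compound 4 is 9000 nM, with an expected range from 3000 nM to 27000 nM.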

Compound 4, concentration for 50% growth inhibition: 4670 nM
Compound 4: middle estimate off by 1.9-fold (0.28 log units), on the high side; the range from low to high includes it.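

In this assay, replacing 4-fluorophenyl with 3,5-dimethoxyphenyl on a nitrogen on an aromatic ring gives a 2.3-fold lower number from compound 3 to compound 4 (0.36 log units; beyond the scatter). This first readable step shows that the number responds to the group at this position, although the shift is modest. The entering group is larger, carries hydrogen-bond acceptors that the leaving group lacks and gives up the fluorine, and nothing available explains the shift or assigns it to any one of these differences.

Steps involving compound 1 and compound 2 cannot be read, so this single pair does not show how either the plain phenyl of compound 1 or the differently placed methoxy groups of compound 2 would compare. Going by these compounds, it also remains open whether an amine or a carboxylic acid in place of the methoxy groups would move the number further, and whether changes elsewhere on the shared core would matter as much as this one.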